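The source may report more compounds than this note shows. Statements on the series, on what has been measured and on what is new or still open speak of the compounds shown alone.

Compound 1, with the structure `Oc1ccccc1CNc1ccc(-c2ccc(-c3ccccc3)cc2)cc1`, is the starting point of this account. In a functional assay on Jurkat cells (Homo sapiens) for activation, with a stated time of 24 h (on this read-out higher numbers stand for an effect only at larger amounts of compound and lower numbers for an effect already at smaller amounts), compound 1 gives "not active" (no number reported), so no single number can be set down for it; it stands at the inactive end of what has been seen so far. A second measured compound, compound 2 with the structure `CCOc1ccc(-c2ccc(NCc3ccccc3O)cc2)cc1F`, gives 2530 nM in this assay. The untested compound 3 has the structure `CCCOc1ccc(-c2ccc(NCc3ccccc3O)cc2)cc1`. Compound 3 differs from compound 1 by propoxy in place of phenyl on an aromatic carbon. For the measured compounds named here, no measured pair shows this exact change, so its size is not known; the expectation is that compound 3 moves away from the inactive standing of compound 1 toward lower numbers in this assay, by an amount that cannot be set from the data at hand. Compound 3 is estimated at 3500 nM, within a range from 800 nM to 15000 nM.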

Compound 3, half-maximal effective concentration: "not active" (no number reported)
Compound 3: no number reported, so the estimate cannot be set against anything.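

Compound 1 and compound 3 carry no number in this assay, so no step can be read between them. Nothing measured here bears on this result. The compounds shown leave open whether propoxy in place of phenyl shifts the response at all.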